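Removing a methyl from the phenolic oxygen of compound 2

A few compounds are considered here, and "the series" means these few. Any claim that something is new, unique, unknown or untested is made for them only; others in the source may bear on it.

Of the compounds shown here, two have been measured in a functional assay on UACC-257 cells (Homo sapiens) for inhibition, read by sulforhodamine B assay, with a stated time of 48 h; a lower number here means a stronger inhibitor of growth, a higher number a weaker inhibitor of growth. Compound 1 `O=C(Nc1cccc(-n2cc(-c3ccncc3)c(-c3ccc(Cl)c(O)c3)n2)c1)Nc1cccc(C(F)(F)F)c1` gives 4340 nM. Compound 2 `COc1cc(-c2nn(-c3cccc(NC(=O)Nc4ccc(Cl)c(C(F)(F)F)c4)c3)cc2-c2ccncc2)ccc1Cl` gives 1210 nM, the lower of the two numbers, and its gap to compound 1 lies beyond the scatter. Compound 3 `O=C(Nc1cccc(-n2cc(-c3ccncc3)c(-c3ccc(Cl)c(O)c3)n2)c1)Nc1ccc(Cl)c(C(F)(F)F)c1` has not been measured; it differs from compound 2 by hydrogen in place of methyl on an oxygen on an aromatic ring. Among the measured compounds shown here, no measured pair shows this change, so only a modest step is expected from compound 2 to compound 3 in this assay a 1.5-fold higher number from compound 2 to compound 3 (0.17 log units; within the scatter), likely within or just beyond the scatter. Compound 3 is therefore estimated at 1800 nM, within 700 nM to 4500 nM.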

Compound 3, concentration for 50% growth inhibition: 768 nM
Beside the measured number, compound 3's estimate is 2.3-fold (0.37 log units) above it; the measured number falls inside the stated range.
By their numbers in this assay, from the lowest: compounds 3 and 2 (each within the scatter of the next); then compound 1.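

In this assay hydrogen in place of methyl on the oxygen gives a 1.6-fold lower number from compound 2 to compound 3 (0.20 log units; within the scatter) so methoxy and hydroxy are not told apart at this position. With the hydroxy held constant, chloro in place of hydrogen on an aromatic carbon gives a 5.7-fold lower number from compound 1 to compound 3 (0.75 log units; beyond the scatter) and this change therefore separates the two hydroxy compounds. Nothing given here explains either step. Going by these compounds, how an ethoxy group or an amine at the hydroxy position would read in this assay stays open. So does whether the chloro step holds with methoxy in place of hydroxy.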